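This account rests on a few compounds, and the source may have more. Where it says the series, first, only, none or still open, it means among the compounds named here.

In an ADME assay on L6 cells (Rattus norvegicus) for cytotoxicity (on this read-out higher numbers stand for weaker inhibition and lower numbers for stronger inhibition), compound 3 `N#Cc1ccccc1N1CCN(C(=O)Cn2cnc([N+](=O)[O-])n2)CC1` gives 213000 nM. Compound 1 `Cc1ccc(N2CCN(CC(=O)N3CCN(c4ccc(C)cc4)CC3)CC2)cc1` gives 213000 nM, a number that stands level with compound 3 within the usual scatter, and together these two sit at the top of the three values. Compound 2 `O=C(CN1CCN(c2ccc(Cl)c(Cl)c2)CC1)N1CCN(c2ccc(Cl)c(Cl)c2)CC1` gives 20200 nM, a lower number whose gap to compound 3 lies beyond the scatter. Compound 4 `Cc1ccc(N2CCN(C(=O)Cn3cnc([N+](=O)[O-])n3)CC2)cc1` has not yet been measured in this assay. It differs from compound 3 in one place: 4-methylphenyl in place of 2-cyanophenyl on an amine nitrogen in a ring. Compound 1, which also carries 4-methylphenyl, gave 213000 nM, the same as compound 3. Compound 4 is therefore expected to show no step beyond the scatter, no change at the digits printed from compound 3 to compound 4 (within the scatter), and its estimated value is 213000 nM, with a range from 100000 nM to 400000 nM.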

Compound 4, half-maximal inhibitory concentration: 148000 nM
The estimate for compound 4 lay 1.4-fold (0.16 log units) above the measured number; the measured number falls inside the stated range.
By their numbers in this assay, from the lowest: compound 2; then compounds 4, 1 and 3 (each within the scatter of the next).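

In this assay, 4-methylphenyl in place of 2-cyanophenyl on the amine nitrogen of the ring gives a 1.4-fold lower number from compound 3 to compound 4 (0.16 log units; within the scatter) and so leaves the read-out unchanged within the scatter. For the compounds shown here, this is the first comparison at this position with everything else held constant, and it shows that the nitrile on the aromatic ring can go without a step beyond the scatter. Nothing measured here offers an explanation for this result.

The compounds shown leave open whether a carboxylic acid or an amine on that phenyl ring would stay level with compound 3. They also leave open whether replacing the phenyl ring with a saturated carbon chain would do so.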